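The source may hold more compounds than are shown below. What is called first, only, known or untested is meant among the compounds shown, and "the series" means these compounds.

Of the compounds shown here, three built on one shared core have been measured in an assay on isolated protein (strain albino) for antagonist activity at Voltage-dependent L-type calcium channel subunit alpha-1C (Cavia porcellus); on this read-out higher numbers stand for weaker inhibition and lower numbers for stronger inhibition. Compound 1 `CCOC(=O)C1=C(C)NC(C)=C(C(=O)OCc2ccccc2)C1c1cnc(SC)n1Nc1ccccc1` gives 1.86 nM. Compound 2 `CCOC(=O)C1=C(C)NC(C)=C(C(=O)OCCCc2ccccc2)C1c1cnc(SC)n1Nc1ccccc1` gives 2.54 nM; it arises from compound 1 by phenethyl in place of phenyl on a saturated chain carbon bound to an oxygen next to a carbonyl group, and the step is a 1.4-fold higher number from compound 1 to compound 2 (0.14 log units; within the scatter). Compound 3 `CSc1ncc(C2C(C(=O)OCc3ccccc3)=C(C)NC(C)=C2C(=O)OC(C)C)n1Nc1ccccc1` gives 7.24 nM; the core of compound 3 differs from the core of compound 1 by methyl in place of hydrogen on a saturated chain carbon bound to an oxygen next to a carbonyl group and a saturated chain carbon, and the step is a 3.9-fold higher number from compound 1 to compound 3 (0.59 log units; beyond the scatter). Among the three measured compounds, compound 3 carries the highest number, beyond the scatter from both compound 1 and compound 2.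

Compound 4 `CSc1ncc(C2C(C(=O)OCCCc3ccccc3)=C(C)NC(C)=C2C(=O)OC(C)C)n1Nc1ccccc1` has not yet been measured. It differs from compound 3 by phenethyl in place of phenyl on a saturated chain carbon bound to an oxygen next to a carbonyl group, the same change that carried compound 1 to compound 2, at a place described in the same words in both pairs. Because that earlier change gave a 1.4-fold higher number from compound 1 to compound 2 (0.14 log units; within the scatter), a step of similar size is expected here, a 1.4-fold higher number from compound 3 to compound 4 (0.14 log units; within the scatter). Within the data shown here, this expectation rests on the one earlier pair only. Compound 4 is therefore estimated at 10 nM, expected to fall between 4.5 nM and 24 nM.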

Compound 4, half-maximal inhibitory concentration: 6.22 nM
Beside the measured number, compound 4's estimate is 1.6-fold (0.21 log units) above it; measured number inside the range.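

In this assay, phenethyl in place of phenyl on a saturated chain carbon bound to an oxygen next to a carbonyl group gives a 1.2-fold lower number from compound 3 to compound 4 (0.07 log units; within the scatter), which agrees with the same change on the core of compound 1: the same change on two cores in this assay, a 1.4-fold higher number (0.14 log units; within the scatter) from compound 1 to compound 2 and a 1.2-fold lower number (0.07 log units; within the scatter) from compound 3 to compound 4, 1.6-fold (0.20 log units) apart, within the scatter of two such steps. The second change gives a 2.4-fold higher number from compound 2 to compound 4 (0.39 log units; beyond the scatter), and it too carries over between cores: the same change on two cores in this assay, a 3.9-fold higher number (0.59 log units; beyond the scatter) from compound 1 to compound 3 and a 2.4-fold higher number (0.39 log units; beyond the scatter) from compound 2 to compound 4, 1.6-fold (0.20 log units) apart, within the scatter of two such steps. Across compounds 1 to 4, each change therefore reads alike on both cores, but each comparison rests on only two steps, and this shows nothing about any other core or any other change.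

The compounds shown leave open how an amine on the chain, or a chain longer than 3-phenylpropyl, would read in this series. They also leave open whether a carboxylic acid in place of the benzyloxycarbonyl group would keep a number in the same range.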